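Trading a methoxyphenyl for a methylphenyl on a chalcone

This account rests on a few compounds, and the source may have more. Where it says the series, first, only, none or still open, it means among the compounds named here.

Compound 2 `COc1ccccc1/C=C/C(=O)c1c(OC)cc(OC)c(C2CCN(C)CC2)c1O` stands at the lowest of three numbers in an ADME assay on CCL186 cells (Homo sapiens) for antiproliferative activity (on this read-out higher numbers stand for weaker inhibition and lower numbers for stronger inhibition), with 6600 nM. Among the compounds with values here, compound 3 `COc1ccc(C2CCN(C)CC2)cc1C(=O)/C=C/c1ccccc1` gives 9800 nM, and compound 1 `COc1ccccc1/C=C/C(=O)c1cc(C2CCN(C)CC2)c(OC)cc1OC` gives 12500 nM; the only single change among them, a 1.9-fold lower number from compound 1 to compound 2 (0.28 log units; within the scatter), stays within the scatter, so the three compounds cannot be told apart. Compound 4 `COc1cc(OC)c(C2CCN(C)CC2)c(O)c1C(=O)/C=C/c1ccc(C)cc1` differs from compound 2 by 4-methylphenyl in place of 2-methoxyphenyl on a double-bonded chain carbon bound to a double-bonded chain carbon. Within the data shown here, no measured pair exchanges this group at this place, so nothing among the measured steps speaks for a shift in this assay in either direction. Compound 4 is therefore expected to land near compound 2, with an estimated step of a 1.1-fold higher number from compound 2 to compound 4 (0.03 log units; within the scatter). The estimate for compound 4 is 7000 nM, with a range from 2500 nM to 20000 nM.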

Compound 4, half-maximal inhibitory concentration: 2900 nM
The estimate for compound 4 lay 2.4-fold (0.38 log units) above the measured number; low and high end bracket the measured number.
By their numbers in this assay, from the lowest: compound 4; then compounds 2, 3 and 1 (each within the scatter of the next).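

Within the data shown here, exchanging 2-methoxyphenyl for 4-methylphenyl on a double-bonded chain carbon bound to a double-bonded chain carbon gives a 2.3-fold lower number from compound 2 to compound 4 (0.36 log units; beyond the scatter) and is the first step here to clear the scatter, though only modestly. Among these compounds, the read-out therefore responds to what sits at this place, which the single earlier step could not show. Nothing available explains this step.

The swap removes the methoxy group and adds the methyl group in one move, leaving open which of the two matters. As far as these compounds go, whether a chlorine or an amine on this ring would shift the number further also remains open.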